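Halogen Returns on the Aryl Ring of the Dienone

The compounds below may be only part of what the source reports. "The series", "measured", "known", "first", "only" and "open" are said of these compounds alone.

Among the compounds with values here, compound 2 `CC1=C(/C=C/C(=O)/C=C/c2ccc(C)cc2)C(C)(C)CCC1` gives the highest of the two numbers measured so far in a functional assay on PC-3 cells (Homo sapiens) for cytotoxicity, read by sulforhodamine B assay, with a stated time of 48 h (a higher number here means a weaker inhibitor, a lower number a stronger inhibitor), namely 21500 nM; its nearest neighbour, compound 1 `CC1=C(/C=C/C(=O)/C=C/c2ccc(Cl)cc2)C(C)(C)CCC1`, gives 9500 nM in this assay. Within the data shown here, the one measured step, a 2.3-fold higher number from compound 1 to compound 2 (0.35 log units; beyond the scatter), is modest and beyond the scatter. Compound 3 `CC1=C(/C=C/C(=O)/C=C/c2ccccc2Br)C(C)(C)CCC1` differs from compound 2 by 2-bromophenyl in place of 4-methylphenyl on a double-bonded chain carbon bound to a double-bonded chain carbon. Among the measured compounds shown here, the measured step bears on this change only in part: it shows that a halogen on the aromatic ring went with a lower number than a methyl, but no measured compound carries a 2-bromophenyl, so the rest of the change is untested. A step back toward the halogen is therefore expected, but a small one with wide uncertainty. Compound 3 is estimated at 12000 nM, with a range from 5000 nM to 30000 nM. This means an expected step of a 1.8-fold lower number from compound 2 to compound 3 (0.25 log units; within the scatter).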

Compound 3, half-maximal inhibitory concentration: 11400 nM
Beside the measured number, compound 3's estimate is 1.1-fold (0.02 log units) above it; low and high end bracket the measured number.
By their numbers in this assay, from the lowest: compounds 1, 3 and 2 (each within the scatter of the next, the first and the last beyond it).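

Replacing 4-methylphenyl with 2-bromophenyl gives a 1.9-fold lower number from compound 2 to compound 3 (0.28 log units; within the scatter), and replacing 4-chlorophenyl with 2-bromophenyl gives a 1.2-fold higher number from compound 1 to compound 3 (0.08 log units; within the scatter), so neither change is separated from the scatter. In this assay, compound 3 thus cannot be told apart from compound 1 or from compound 2, even though those two compounds stand apart from each other, and the 2-bromophenyl group adds no step beyond the scatter at this double-bonded chain carbon. No measurement offered here accounts for this result.

The three compounds leave open how much of the reading depends on the halogen and how much on the rest of the aryl group. They also leave open how an unsubstituted phenyl, or an aryl ring carrying an amine or a carboxylic acid, would read in this assay.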